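This account rests on a few compounds, and the source may have more. Where it says the series, first, only, none or still open, it means among the compounds named here.

Measured in an ADME assay on Raji cells (Homo sapiens) for cytotoxicity, with a stated time of 72 h (a lower number here means that less compound is needed, a higher number that more compound is needed for the effect), each entry a limit and not a number:

- compound 1 `Cc1cc(NC(=O)Nc2ccc(C(C)(C)C)cc2)c2ccccc2n1`: > 25000 nM
- compound 2 `Cc1cc(NC(=O)Nc2ccccc2OC(F)(F)F)c2ccccc2n1`: > 25000 nM
- compound 3 `COc1ccc(NC(=O)Nc2cc(C)nc3ccccc23)cc1OC`: > 25000 nM

Going by the values given here, the series so far stands at the limit of > 25000 nM in this assay, at which 3 of the 3 values shown sit. Compound 1 has only a limit, > 25000 nM, so its position marks where the measurable range ends and gives no exact value. Among the compounds with values here, no step between measured compounds is available to size a single structural change.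

The next compound is compound 4 `Cc1ccc(NC(=O)Nc2cc(C)nc3ccccc23)cc1`. It carries methyl in place of tert-butyl on an aromatic carbon of a six-membered aromatic ring of carbon only, para to a large group (methyl in place of tert-butyl on an aromatic carbon).

No shift beyond the scatter is expected in this assay, in either direction. This expectation rests on compound 3, whose limit is > 25000 nM and which has no tert-butyl. The estimated step is a number no higher from compound 1 to compound 4 (the limit leaves the size open). A reported limit is the likeliest outcome. For compound 4 the expected value is 25000 nM, with an estimated range of 10000 nM to 50000 nM.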

Compound 4, half-maximal effective concentration: > 25000 nM
Compound 4 was reported as a limit; the forecaster's own chance of this, stated with the estimate: 80%; the middle value lies on the limit itself.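

In this assay compound 4 gives > 25000 nM, which is a limit. Going by these compounds alone, compound 1 is also reported only as a limit, so no step from compound 1 to compound 4 can be read. The compounds shown leave open which structural change, if any, gives a measurable value: the limit of > 25000 nM in this assay, at which 4 of the 4 values shown sit.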